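A few compounds are considered here, and "the series" means these few. Any claim that something is new, unique, unknown or untested is made for them only; others in the source may bear on it.

Measured so far:
compound 1 `COc1cc(NC(=O)Nc2cccc3c(Nc4cc(OC)cc(OC)c4)ncnc23)cc(OC)c1`: 366 nM
compound 2 `COc1cc(Nc2ncnc3c(NC(=O)Nc4cccc(Cl)c4Cl)cccc23)cc(OC)c1`: 63.2 nM
compound 3 `COc1cc(Nc2ncnc3c(NC(=O)Nc4cc(C)cc(C)c4)cccc23)cc(OC)c1`: 10100 nM

These numbers come from a functional assay on RT-112 cells (Homo sapiens) for antiproliferative activity, read by MTT assay, with a stated time of 72 h; a lower number here means a stronger inhibitor of growth, a higher number a weaker inhibitor of growth. Compound 2 gives the lowest number of the three, as shown by a 5.8-fold lower number from compound 1 to compound 2 (0.76 log units; beyond the scatter) and by a 160-fold higher number from compound 2 to compound 3 (2.20 log units; beyond the scatter). For the measured compounds named here, compound 4 `COc1cc(Nc2ncnc3c(NC(=O)c4cc(=O)c5ccccc5o4)cccc23)cc(OC)c1` differs from compound 2 in one place: a group of 11 heavy atoms (9 carbon, 2 oxygen; one six-membered aromatic ring of carbon only, one six-membered aromatic ring with 1 hetero atom) in place of a group of 9 heavy atoms (6 carbon, 1 nitrogen, 2 chlorine; one six-membered aromatic ring of carbon only), on a carbonyl carbon No measured step makes a change of this kind; all three swap one aromatic ring for another on an amide-type nitrogen, and their spread is wide, as a 28-fold higher number from compound 1 to compound 3 (1.44 log units; beyond the scatter) shows. The step in this assay therefore cannot be read off directly, and compound 2 already stands lowest, leaving more room for a higher number than a lower one. Compound 4 is expected to give 600 nM, in a range of 80 nM to 5000 nM. That estimate means an expected 9.5-fold higher number from compound 2 to compound 4 (0.98 log units; beyond the scatter).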

Compound 4, concentration for 50% growth inhibition: > 20000 nM
Compound 4: no number, only a limit (the forecaster's own chance of this, stated with the estimate: 5%); at least 33-fold (1.52 log units) between middle value and limit.
By their numbers in this assay, from the lowest: compound 2; then compound 1; then compound 3. At a limit, above all of these: compound 4.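

In this assay compound 4 gives > 20000 nM, which is a limit of the assay and not a number. Putting this new group with its two six-membered aromatic rings on the carbonyl carbon gives an at least 310-fold higher number from compound 2 to compound 4 (2.50 log units; beyond the scatter) and an at least 54-fold higher number from compound 1 to compound 4 (1.73 log units; beyond the scatter), so a change at this place can cost far more than compound 2 or compound 1 would suggest. The third step, an at least 1.9-fold higher number from compound 3 to compound 4 (0.29 log units; that floor lies within the scatter), sets no clear order for that pair.

Left open is how a plain phenyl group or a piperidine amine on the carbonyl carbon would behave, and so whether the loss follows the departure of the amide-type nitrogen or the arrival of the new ring group.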